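This account rests on a few compounds, and the source may have more. Where it says the series, first, only, none or still open, it means among the compounds named here.

Measured compounds in an assay on HEK293 cells for inhibition of Leucine-rich repeat serine/threonine-protein kinase 2 (Homo sapiens), with a stated time of 48 h; a lower number here means a stronger inhibitor, a higher number a weaker inhibitor:
compound 1 `Cc1c(Nc2nc(N)c3c(C#N)c(N4CCC[C@H]4C)n(C)c3n2)cnn1C`: 310 nM
compound 2 `Cc1c(Nc2nc(N)c3c(C#N)c(N4CCC[C@H]4C)n(C)c3n2)cnn1[C@H]1CCOC1`: 140 nM
compound 3 `Cc1c(Nc2nc(N)c3c(C#N)c(N4CCC[C@H]4C)n(C)c3n2)cnn1CC1(O)COC1`: 220 nM

Compound 1 gives the highest number of the three; the gap to compound 3 is within the scatter, whereas a 2.2-fold lower number from compound 1 to compound 2 (0.35 log units; beyond the scatter) lies beyond it.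

Compound 4 `C[C@@H]1CCCN1c1c(C#N)c2c(N)nc(Nc3cn(C)nc3C(F)(F)F)nc2n1C` differs from compound 1 by 1-methyl-3-(trifluoromethyl)-1H-pyrazol-4-yl in place of 1,5-dimethyl-1H-pyrazol-4-yl on a nitrogen on an aromatic ring. Within the data shown here, no measured step touches the substituents on the pyrazole ring carbons; the known steps, a 2.2-fold lower number from compound 1 to compound 2 (0.35 log units; beyond the scatter) and a 1.4-fold lower number from compound 1 to compound 3 (0.15 log units; within the scatter), only vary the group on the pyrazole nitrogen and stay modest. They therefore give no direct guide, and no step beyond the scatter is expected in this assay for compound 4.

Compound 4 is estimated at 350 nM (range 150 nM to 900 nM), corresponding to an expected 1.1-fold higher number from compound 1 to compound 4 (0.05 log units; within the scatter).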

Compound 4, half-maximal inhibitory concentration: 910 nM
The estimate for compound 4 lay 2.6-fold (0.41 log units) below the measured number, outside the stated range (above it).
By their numbers in this assay, from the lowest: compounds 2, 3 and 1 (each within the scatter of the next, the first and the last beyond it); then compound 4.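

In this assay, replacing 1,5-dimethyl-1H-pyrazol-4-yl with 1-methyl-3-(trifluoromethyl)-1H-pyrazol-4-yl gives a 2.9-fold higher number from compound 1 to compound 4 (0.47 log units; beyond the scatter), so this position can move the number beyond the scatter. Among these compounds, this is the only step from compound 1 towards a higher number, whereas changes to the group on the pyrazole nitrogen gave lower numbers. No available data bear on the reason for this shift.

As far as these compounds go, it remains open whether chlorine, ethyl or a nitrile in place of trifluoromethyl would behave the same way. Also open, from the compounds shown here alone, is whether oxolan-3-yl on the pyrazole nitrogen would still lower the number with trifluoromethyl present.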